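This account rests on a few compounds, and the source may have more. Where it says the series, first, only, none or still open, it means among the compounds named here.

Measured compounds and values in this assay:
compound 1, `Cn1cnc2ccccc2c1=S`: 22%
compound 2, `Cn1cnc2nc(-c3ccccc3)nn2c1=S`: 1%
compound 3, `Cn1cnc2nc(-c3ccc(Cl)cc3)nn2c1=S`: 92%

In a functional assay on the whole organism for inhibition, with Rattus norvegicus as the target, at a dose of 30 mg/kg by the intraperitoneal route (on this read-out higher numbers stand for more inhibition at the one dose given (going by the name of the read-out) and lower numbers for less inhibition), compound 1 gives 22%, compound 2 gives 1% and compound 3 gives 92%. Compound 3 stands highest of the three numbers; compound 1 is nearest to it and compound 2 furthest, both gaps beyond the scatter. Going by the values given here, the only single-point step among the measured compounds is a number 91 percentage points higher from compound 2 to compound 3 (beyond the scatter).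

Compound 4, `Cn1cnc2nc(-c3ccc(C#N)cc3)nn2c1=S`, is not yet measured in this assay. It differs from compound 3 by cyano in place of chloro on an aromatic carbon. Among the compounds with values here, the step from compound 2 to compound 3 bears on this change in that it shows how much the chloro group alone contributes on the shared core of compounds 2 and 3; no measured compound carries a cyano group, so the data hold no step for cyano itself. As far as these compounds go, because a number 91 percentage points higher from compound 2 to compound 3 (beyond the scatter) was large, taking the chloro group away is expected to cost inhibition, and how much of that loss the cyano group recovers is unknown. Compound 4 is therefore expected to give 55%, with a wide range from 10% to 95%. The step this estimate means is a number 37 percentage points lower from compound 3 to compound 4 (beyond the scatter), expected downward but uncertain in size.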

Compound 4, a percentage reported as inhibition, in the whole organism at one dose (the size of the read-out at that dose, not a potency): 79%
Compound 4: the middle estimate sits 24 percentage points below what was measured, and the stated range covers the measured number.
By their numbers in this assay, from the lowest: compound 2; then compound 1; then compound 4; then compound 3.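

In this assay, the large gain at this position is no longer tied to chloro alone: the second replacement of hydrogen on this aromatic carbon, para to a large group, gives a number 78 percentage points higher from compound 2 to compound 4 (beyond the scatter) and so stands close in size to a number 91 percentage points higher from compound 2 to compound 3 (beyond the scatter). Exchanging the two groups directly adds a heavy atom, a triple bond and a hydrogen-bond acceptor, yet it gives only a number 13 percentage points lower from compound 3 to compound 4 (beyond the scatter) and so, while beyond the scatter, this modest loss is small beside either gain over hydrogen. Nothing available explains either the gains or the gap between chloro and cyano.

The compounds shown place only hydrogen, chloro and cyano on this carbon, so it remains open whether a methoxy group, an amine or a carboxylic acid there would keep the inhibition or lose it. Also open, as far as these compounds go, is whether chloro or cyano would give similar numbers at another carbon of the same ring, and, with one dose as the only read-out, how compound 3 and compound 4 would compare in potency.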